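This account rests on a few compounds, and the source may have more. Where it says the series, first, only, none or still open, it means among the compounds named here.

Measured so far in a functional assay on DU-145 cells (Homo sapiens) for cytotoxicity, read by sulforhodamine B assay, with a stated time of 48 h; a lower number here means a stronger inhibitor of growth, a higher number a weaker inhibitor of growth:

- compound 1 `CC1CC(C)CN(c2nc(Nc3ccc(C#N)c(C(F)(F)F)c3)nc(Oc3ccnc4ccccc34)n2)C1`: 27200 nM
- compound 2 `N#Cc1ccc(Nc2nc(Oc3ccnc4ccccc34)nc(N3CCN(c4cccc(C(F)(F)F)c4)CC3)n2)cc1C(F)(F)F`: 38700 nM
- compound 3 `N#Cc1ccc(Nc2nc(Oc3ccnc4ccccc34)nc(N3CCN(c4ccccc4F)CC3)n2)cc1C(F)(F)F`: a limit of the assay, > 100000 nM

Compound 1 stands together with compound 2; the gap between the two numbers lies within the scatter. Compound 3 gives only a limit (the limit of > 100000 nM in this assay, at which 1 of the 3 values shown sits). Going by the values given here, the one measured step, an at least 2.5-fold higher number from compound 2 to compound 3 (0.41 log units; beyond the scatter), changes the group on the amine nitrogen of the second ring and leaves the ring attached to the shared core untouched.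

Compound 4 `N#Cc1ccc(Nc2nc(Oc3ccnc4ccccc34)nc(N3CCCCC3)n2)cc1C(F)(F)F` differs from compound 1 by piperidin-1-yl in place of 3,5-dimethylpiperidin-1-yl on an aromatic carbon. Among the compounds with values here, no measured step changes this part of the structure, so there is nothing of the same kind to lean on; the only step in hand concerns a different position and a different kind of change. Within the data shown here, the removal of the two methyl groups is a small change in size, and no step shows its effect. A step of no more than modest size is expected, in no set direction, with a 1.3-fold higher number from compound 1 to compound 4 (0.11 log units; within the scatter). Compound 4 is estimated at 35000 nM, within 12000 nM to 100000 nM, in this assay.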

Compound 4, concentration for 50% growth inhibition: 94900 nM
Beside the measured number, compound 4's estimate is 2.7-fold (0.43 log units) below it; the measured number falls inside the stated range.
By their numbers in this assay, from the lowest: compounds 1 and 2 (each within the scatter of the next); then compound 4. At a limit, above all of these: compound 3.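

In this assay, the two methyl groups of 3,5-dimethylpiperidin-1-yl are shown to matter: piperidin-1-yl in its place gives a 3.5-fold higher number from compound 1 to compound 4 (0.54 log units; beyond the scatter). Going by these compounds alone, this is the first step read at this position on the shared core, and it shows that even a change this small in heavy atoms moves the number beyond the scatter, with the higher number on the side without the methyl groups. Further steps upward from compound 4 have little room to be read as numbers, as the assay ends in a limit: the limit of > 100000 nM in this assay, at which 1 of the 4 values shown sits.

Going by these compounds, whether one methyl group would suffice stays open, and piperidin-1-yl carrying a single methyl group would address that. Also open, on these data alone, is how a morpholine or a larger alkyl-substituted piperidine would read at this position.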